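This account rests on a few compounds, and the source may have more. Where it says the series, first, only, none or still open, it means among the compounds named here.

Measured in a functional assay on HeLa cells (Homo sapiens) for antiproliferative activity, read by MTT assay, with a stated time of 48 h; on this read-out lower numbers stand for stronger inhibition and higher numbers for weaker inhibition:

- compound 1 `O=[N+]([O-])c1ccccc1CSc1nnc(-c2ccc3c(c2)OCCO3)o1`: 32700 nM
- compound 2 `Fc1ccc(CSc2nnc(-c3ccc4c(c3)OCCO4)o2)cc1`: 41200 nM
- compound 3 `Clc1ccc(CSc2nnc(-c3ccc4c(c3)OCCO4)o2)cc1`: 28500 nM

The three values lie within the scatter of one another, so compound 3 holds no distinct place among them and no order can be drawn.

The next compound is compound 4 `Clc1ccccc1CSc1nnc(-c2ccc3c(c2)OCCO3)o1`, which has 2-chlorophenyl in place of 4-chlorophenyl on a saturated chain carbon bound to a sulfur. The two structures have the same atoms, joined differently. Within the data shown here, no measured pair tests this kind of change directly. The nearest evidence is a different change, chloro in place of fluoro on an aromatic carbon, which gave a 1.4-fold lower number from compound 2 to compound 3 (0.16 log units; within the scatter). Among the measured compounds shown here, with only that small step to go on, no shift beyond the scatter is expected in this assay, and no direction can be argued.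

The expected step is a 1.1-fold higher number from compound 3 to compound 4 (0.02 log units; within the scatter). The estimate for compound 4 is 30000 nM, with an expected range of 16000 nM to 56000 nM.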

Compound 4, half-maximal inhibitory concentration: 36800 nM
The estimate for compound 4 lay 1.2-fold (0.09 log units) below the measured number; the range from low to high includes it.
By their numbers in this assay, from the lowest: compounds 3, 1, 4 and 2 (each within the scatter of the next).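

In this assay, 2-chlorophenyl in place of 4-chlorophenyl on a saturated chain carbon bound to a sulfur gives a 1.3-fold higher number from compound 3 to compound 4 (0.11 log units; within the scatter), so this direct test finds no separation between the two chlorophenyl isomers. The 2-chlorophenyl compound also stays within the scatter of the 4-fluorophenyl compound (a 1.1-fold lower number from compound 2 to compound 4 (0.05 log units; within the scatter)) and of the nitro compound (a 1.1-fold higher number from compound 1 to compound 4 (0.05 log units; within the scatter)), so neither the change of group nor the change of its place moves the number beyond the scatter in these pairs. No supporting data are available to explain this flat result.

Open, going by these compounds, is whether an amine or a carboxylic acid in place of chloro on the aromatic carbon would move the number beyond the scatter. Also open, on these data alone, is whether a longer chain in place of the benzyl link would do so.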